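The compounds below may be only part of what the source reports. "The series", "measured", "known", "first", "only" and "open" are said of these compounds alone.

Measured compounds in a functional assay on HCT-15 cells (Homo sapiens) for inhibition, read by MTT assay, with a stated time of 72 h; on this read-out higher numbers stand for weaker inhibition and lower numbers for stronger inhibition:
compound 1 `COc1ccc(CNCc2c(OC)cc(Oc3cccc(Nc4ccccc4)c3)cc2OC)cc1` gives 2650 nM
compound 2 `COc1cc(Oc2cccc(Nc3ccccc3)c2)cc(OC)c1CNCc1ccccc1` gives 5020 nM
compound 3 `COc1cc(Oc2cccc(Nc3ccccc3)c2)cc(OC)c1CN(C)C` gives 15600 nM

Compound 3 stands at the highest number of the three, and its steps to the other two both lie beyond the scatter, so it is the weakest inhibitor measured so far in this assay. The step to the unmeasured compound 4 `COc1cc(Oc2cccc(Nc3ccccc3)c2)cc(OC)c1CNCc1ccc(O)cc1` is (4-hydroxybenzyl)amino in place of dimethylamino on a saturated chain carbon bound to an aromatic carbon.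

For the measured compounds named here, two measured steps bear on this change. Going from compound 1 to compound 3 the dimethylamino replaced the (4-methoxybenzyl)amino with a 5.9-fold higher number from compound 1 to compound 3 (0.77 log units; beyond the scatter); going from compound 2 to compound 3 it replaced the benzylamino with a 3.1-fold higher number from compound 2 to compound 3 (0.49 log units; beyond the scatter). Both benzylamino variants therefore sit at lower numbers than compound 3, and the gap between them, a 1.9-fold higher number from compound 1 to compound 2 (0.28 log units; within the scatter), is within the scatter. A (4-hydroxybenzyl)amino group is expected to behave like these two, so the number for compound 4 is expected to fall by a modest amount, about a 4.5-fold lower number from compound 3 to compound 4 (0.65 log units; beyond the scatter). For compound 4 in this assay the estimate is 3500 nM, with a range from 1500 nM to 8000 nM.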

Compound 4, half-maximal inhibitory concentration: 3430 nM
Compound 4: middle estimate off by 1.0-fold (0.01 log units), on the high side; measured number inside the range.
By their numbers in this assay, from the lowest: compounds 1, 4 and 2 (each within the scatter of the next); then compound 3.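

In this assay, (4-hydroxybenzyl)amino in place of dimethylamino on a saturated chain carbon bound to an aromatic carbon gives a 4.5-fold lower number from compound 3 to compound 4 (0.66 log units; beyond the scatter), so a third benzylamino variant stands apart from compound 3. Hydroxy in place of hydrogen on an aromatic carbon gives a 1.5-fold lower number from compound 2 to compound 4 (0.17 log units; within the scatter), and hydrogen in place of methyl on an oxygen on an aromatic ring gives a 1.3-fold higher number from compound 1 to compound 4 (0.11 log units; within the scatter), so in this read-out the hydrogen, methoxy and hydroxy forms of the benzylamino group cannot be told apart. Nothing at hand gives a reason for any of these steps.

The compounds shown leave open whether the lower numbers go with the added aromatic ring or with the hydrogen on the amine nitrogen; methylamino and benzyl(methyl)amino groups would separate the two. Also open, going by these compounds, is whether a carboxylic acid or a chlorine on the benzyl ring would move the number beyond the scatter.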